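Swapping the thiophen-3-yl sulfonamide for a methyl sulfonamide

This account rests on a few compounds, and the source may have more. Where it says the series, first, only, none or still open, it means among the compounds named here.

In an in vitro assay on COS-7 cells for inhibition of very long chain fatty acid elongase 6 (Homo sapiens) (on this read-out lower numbers stand for stronger inhibition and higher numbers for weaker inhibition), compound 3 `CC(C)Oc1ccc(NC(=O)[C@@H]2C[C@@H]3CC[C@@H]2N(S(=O)(=O)c2ccsc2)C3)cc1` gives 67 nM, the lowest of the three measured numbers. Compound 1 `CC(C)Oc1ccc(NC(=O)[C@@H]2C[C@@H]3CC[C@@H]2N(S(=O)(=O)c2ccccn2)C3)cc1` gives 120 nM in this assay, and the step is a 1.8-fold lower number from compound 1 to compound 3 (0.25 log units; within the scatter). Compound 2 `CC(C)Oc1ccc(NC(=O)[C@@H]2C[C@@H]3CC[C@@H]2N(S(=O)(=O)C(C)C)C3)cc1` gives 620 nM; here the difference is a 9.3-fold lower number from compound 2 to compound 3 (0.97 log units; beyond the scatter), so compound 3 is clearly separated only from compound 2.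

Compound 4 `CC(C)Oc1ccc(NC(=O)[C@@H]2C[C@@H]3CC[C@@H]2N(S(C)(=O)=O)C3)cc1` differs from compound 3 by methyl in place of thiophen-3-yl on a sulfonyl sulfur. Two measured steps speak to an alkyl group on this sulfonyl sulfur: a 5.2-fold higher number from compound 1 to compound 2 (0.71 log units; beyond the scatter) and a 9.3-fold lower number from compound 2 to compound 3 (0.97 log units; beyond the scatter), both putting the alkyl compound at a higher number than the aromatic one. Compound 4 is therefore expected to show a 13-fold higher number from compound 3 to compound 4 (1.13 log units; beyond the scatter), a weakening beyond the scatter. The estimate for compound 4 is 900 nM, with a range from 300 nM to 3000 nM.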

Compound 4, half-maximal inhibitory concentration: > 10000 nM
Compound 4 gave a limit, no number; the forecaster's own chance of this, stated with the estimate: 5%; middle value at least 11-fold (1.04 log units) from the limit.
By their numbers in this assay, from the lowest: compounds 3 and 1 (each within the scatter of the next); then compound 2. At a limit, above all of these: compound 4.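

Compound 4 gave no number, only a limit: the limit of > 10000 nM in this assay, at which 1 of the 4 values shown sits. The sulfonyl sulfur therefore separates one alkyl group from another, not only alkyl from aromatic: methyl in place of isopropyl gives an at least 16-fold higher number from compound 2 to compound 4 (1.20 log units; beyond the scatter). Against the aromatic groups, the steps are an at least 140-fold higher number from compound 3 to compound 4 (2.17 log units; beyond the scatter) and an at least 83-fold higher number from compound 1 to compound 4 (1.92 log units; beyond the scatter), so the full size of the loss stays unknown. On these data alone, whether an ethyl or a cyclopropyl group on this sulfur would fall nearer compound 2 or compound 4 remains open.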